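The source may hold more compounds than are shown below. What is called first, only, known or untested is meant among the compounds shown, and "the series" means these compounds.

In a functional assay on the whole organism (Tail, strain ICR) with Mus musculus as the target, in the tail flick test, with a stated time of 30 min, at a dose of 25 umol/kg by the oral route (a higher number here means a stronger effect of the compound at the dose given, a lower number a weaker effect), three compounds have been measured so far. Compound 1 `O=C(CN(c1nc(Cl)nc2[nH]cnc12)C1CC1)N[C@@H](CO)C(=O)OCc1ccccc1` gives 31.9%. Compound 2 `N=C(N)NCCC[C@H](NC(=O)CN(c1nc(Cl)nc2[nH]cnc12)C1CC1)C(=O)O` gives 45.4%. Compound 3 `O=C(CN(c1ncnc2c1ncn2C1CCCCO1)C1CC1)NCC(=O)OCc1ccccc1` gives 55.7%. Among these three numbers compound 1 stands lowest: the nearest to it is compound 2, whose number lies higher by more than the usual scatter, and the furthest is compound 3, higher still and also beyond the scatter.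

Compound 4 `NCCCC[C@H](NC(=O)CN(c1nc(Cl)nc2[nH]cnc12)C1CC1)C(=O)OCc1ccccc1` has not yet been measured in this assay. It differs from compound 1 in one place: 3-aminopropyl in place of hydroxy on a saturated chain carbon, two bonds along the chain from an amide-type nitrogen and a carbonyl carbon. No two of the measured compounds differ from each other in a single place, so the size of such a step has not been seen directly in this set. What the numbers do show is that both compound 2 at 45.4% and compound 3 at 55.7% lie above compound 1, so a change away from compound 1 has so far gone upward rather than downward.

On that basis a modest rise is expected, a number 10.1 percentage points higher from compound 1 to compound 4 (beyond the scatter), roughly bringing compound 4 toward the middle of the measured range. Compound 4 is therefore estimated to give 42% in this assay, with a likely range from 25% to 60%.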

Compound 4, a percentage reported as activity, at one dose (the size of the read-out at that dose, not a potency): 26.1%
The estimate for compound 4 lay 15.9 percentage points above the measured number, and the stated range covers the measured number.
By their numbers in this assay, from the lowest: compounds 4 and 1 (each within the scatter of the next); then compound 2; then compound 3.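

In this assay, going by these compounds alone, this is the first single-place step visible in the set: 3-aminopropyl in place of hydroxy on a saturated chain carbon, two bonds along the chain from an amide-type nitrogen and a carbonyl carbon, gives a number 5.8 percentage points lower from compound 1 to compound 4 (within the scatter) at this one dose. Read one bond further out, hydroxymethyl gives way to 4-aminobutyl, and although the entering group has 4 heavy atoms where the leaving group has 1, this position does not separate the two compounds in this read-out. Nothing available here gives a reason for this result.

The compounds shown leave open whether the amine at the end of the chain matters at all, and a plain butyl chain at this position would test that against compound 4, while a carboxylic acid at the chain end would put a different end group on the same length. Shorter aminoalkyl groups and a longer chain also remain to be seen, so it is unknown how far this position would accept other lengths.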